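The compounds below may be only part of what the source reports. "The series", "measured", "known", "first", "only" and "open" are said of these compounds alone.

Compound 1 `COc1cc(C(=O)c2cn(-c3ccccc3)cc2-c2ccc(Cl)cc2)cc(OC)c1OC` was tested in a functional assay on MCF7 cells (Homo sapiens) for cytotoxicity, read by MTT assay, with a stated time of 96 h (on this read-out higher numbers stand for weaker inhibition and lower numbers for stronger inhibition), where compound 1 gives 290 nM. Compound 2 `COc1cc(C(=O)c2cn(-c3ccccc3)cc2-c2ccc([N+](=O)[O-])cc2)cc(OC)c1OC` differs from it by a single change, (nitro in place of chloro on an aromatic carbon), and in this assay compound 2 gives 590 nM; the step of a 2.0-fold higher number from compound 1 to compound 2 (0.31 log units; beyond the scatter) is modest but beyond the scatter. Compound 3 `COc1cc(C(=O)c2cn(-c3cccc(C)c3)cc2-c2ccccc2Cl)cc(OC)c1OC` carries a different core; the difference between the two cores is not broken down here. In this assay compound 3 gives 420 nM, a number that lies within the scatter of both compound 1 and compound 2, so no order among the three can be claimed from it.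

Compound 4 `COc1cc(C(=O)c2cn(-c3cccc(C)c3)cc2-c2ccccc2[N+](=O)[O-])cc(OC)c1OC` is related to compound 3 by nitro in place of chloro on an aromatic carbon. Going by the values given here, this is the same kind of change as the one from compound 1 to compound 2, but the place differs: there the entering group sat para to a large group, here it sits ortho to a large group. The step from compound 3 to compound 4 is expected to be a 1.9-fold higher number from compound 3 to compound 4 (0.28 log units; within the scatter), resting on the earlier step of a 2.0-fold higher number from compound 1 to compound 2 (0.31 log units; beyond the scatter). Among the compounds with values here, only one such step is known, so the expectation is tempered slightly. On that basis compound 4 is estimated at 800 nM, with an expected range from 400 nM to 1600 nM.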

Compound 4, half-maximal inhibitory concentration: 220 nM
Beside the measured number, compound 4's estimate is 3.6-fold (0.56 log units) above it, outside the stated range (below it).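

In this assay, nitro in place of chloro does not carry over from one core to the other as a fixed step, and the two steps differ in direction: the same change on two cores in this assay, a 2.0-fold higher number (0.31 log units; beyond the scatter) from compound 1 to compound 2 and a 1.9-fold lower number (0.28 log units; within the scatter) from compound 3 to compound 4, 3.9-fold (0.59 log units) apart, beyond the scatter of two such steps

On the second core the change gives a 1.9-fold lower number from compound 3 to compound 4 (0.28 log units; within the scatter), so this pair cannot be told apart in this assay, and the change shows no measurable effect there. This does not show that the core alone sets the outcome: the place of the entering group differs between the two pairs as well, and a single step on each core gives neither a rule nor a reason.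

The compounds shown leave open whether the step would follow the core or the place if the same position were changed on both cores. They also leave open how an amine or a carboxylic acid standing where the chloro stands would read in this assay, on either core.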